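The compounds below may be only part of what the source reports. "The series", "measured", "known", "first", "only" and "open" are said of these compounds alone.

Three measured compounds share a piperidine-linked aminoaryl motif and were tested in a functional assay on CHO-K1 cells for agonist activity at Glucose-dependent insulinotropic receptor (Homo sapiens), read by HTRF and cAMP accumulation, with a stated time of 30 min; a lower number here means that less compound is needed, a higher number that more compound is needed for the effect. Compound 1, `CC(C)(C)OC(=O)N1CCC(CCCCCNc2ccc3c(c2)CCS3(=O)=O)CC1`, gives 145 nM. Compound 2, `CC(C)(C)OC(=O)N1CCC(CCCNc2ccc3c(c2)C(=O)CC3)CC1`, gives 46 nM. Compound 3, `COC(=O)c1cnc(N2CCC(CCCNc3ccc4c(c3)OCC4=O)CC2)nc1`, gives 149 nM. Compound 3 and compound 1 lie within the usual scatter of each other, so no order can be read between them, while compound 2 shows a lower number than compound 3 and that gap is beyond the scatter.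

The compound still to be measured is compound 4, `CC(C)c1nsc(N2CCC(CCCNc3ccc4c(c3)OCC4=O)CC2)n1`. It differs from compound 3 in one place: 3-isopropyl-1,2,4-thiadiazol-5-yl in place of 5-(methoxycarbonyl)pyrimidin-2-yl on an amine nitrogen in a ring. The group that leaves carries an ester on an aromatic ring, and the group that enters carries a branched alkyl on a smaller aromatic ring with three hetero atoms. For the measured compounds named here, no measured pair in this set reports the effect of such an exchange, so the direction of the step can only be inferred from the narrow spread of the three measured values.

Compound 4 is expected to give about 80 nM in this assay, with a plausible range from 20 nM to 400 nM. That estimate means a step from compound 3 to compound 4 of a 1.9-fold lower number from compound 3 to compound 4 (0.27 log units; within the scatter), a modest expected improvement that may not exceed the scatter.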

Compound 4, half-maximal effective concentration: 121 nM
For compound 4 the middle estimate is 1.5-fold (0.18 log units) below the measured one; the measured number falls inside the stated range.
By their numbers in this assay, from the lowest: compound 2; then compounds 4, 1 and 3 (each within the scatter of the next).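

In this assay, putting 3-isopropyl-1,2,4-thiadiazol-5-yl in place of 5-(methoxycarbonyl)pyrimidin-2-yl on an amine nitrogen in a ring gives a 1.2-fold lower number from compound 3 to compound 4 (0.09 log units; within the scatter), so no change can be read from this exchange. For the compounds shown here, this is the first direct comparison at this position, and it shows that a six-membered aromatic ring carrying an ester and a five-membered aromatic ring carrying a branched alkyl group give numbers that cannot be told apart here. No measurement shown explains why the two numbers are so close.

As far as these compounds go, because the ring and its substituent changed in the same step, their separate contributions remain unknown: the ester and the isopropyl group could each matter, with the two effects happening to offset one another, or neither could matter much. From the compounds shown here alone, two groups also say little about the wider range allowed on this nitrogen, so it remains open how a carboxylic acid on the pyrimidine, a methyl group on the thiadiazole or a plain phenyl ring would behave.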